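Neopentyl in Place of a Carbonyl on the Ring Nitrogen

The compounds below may be only part of what the source reports. "The series", "measured", "known", "first", "only" and "open" are said of these compounds alone.

compound 1, `OC(Cc1ccccc1)CN1CCC(NCCSC(c2ccc(F)cc2)c2ccc(F)cc2)CC1`: 309 nM
compound 2, `CC(C)(C)C(=O)N1CCC(NCCSC(c2ccc(F)cc2)c2ccc(F)cc2)CC1`: 163 nM

In an assay on membranes from Cortex for displacement of a labelled ligand from Sigma non-opioid intracellular receptor 1 (Cavia porcellus), read by scintillation counting, with a stated time of 120 min (a higher number here means a weaker inhibitor, a lower number a stronger inhibitor), compound 2 has the lower of the two measured numbers, with compound 1 nearest, yet the step of a 1.9-fold lower number from compound 1 to compound 2 (0.28 log units; within the scatter) stays within the scatter, so the two cannot be ordered. Compound 3, `CC(C)(C)CN1CCC(NCCSC(c2ccc(F)cc2)c2ccc(F)cc2)CC1`, differs from compound 2 in one place: neopentyl in place of (tert-butyl)carbonyl on an amine nitrogen in a ring. Going by the values given here, the only measured step, a 1.9-fold lower number from compound 1 to compound 2 (0.28 log units; within the scatter), touches the same ring nitrogen but exchanges a different pair of groups and stayed within the scatter, so no step beyond the scatter is expected here either. Compound 3 is therefore estimated at 120 nM, with a range of 30 nM to 500 nM, an expected step of a 1.4-fold lower number from compound 2 to compound 3 (0.13 log units; within the scatter).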

Compound 3, inhibition constant: 315 nM
For compound 3 the middle estimate is 2.6-fold (0.42 log units) below the measured one; measured number inside the range.
By their numbers in this assay, from the lowest: compounds 2, 1 and 3 (each within the scatter of the next).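

In this assay, neopentyl in place of (tert-butyl)carbonyl on the amine nitrogen in the ring gives a 1.9-fold higher number from compound 2 to compound 3 (0.29 log units; within the scatter), so the compounds shown reveal no dependence on the carbonyl at this position. The 2-hydroxy-3-phenylpropyl group of compound 1 and the neopentyl group of compound 3 also cannot be told apart, with a 1.0-fold higher number from compound 1 to compound 3 (0.01 log units; within the scatter), so all three groups on this nitrogen remain unresolved. No available evidence bears on this result. Still open, on these data alone, is whether a benzyl group or a carboxylic acid on this nitrogen would give a step beyond the scatter.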